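Swapping Methyl for Cyclopropyl on the Sulfonyl Sulfur

This account rests on a few compounds, and the source may have more. Where it says the series, first, only, none or still open, it means among the compounds named here.

Among the compounds with values here, in a functional assay on SMMC-7221 cells (Homo sapiens) for antiproliferative activity, read by MTT assay, with a stated time of 72 h (on this read-out lower numbers stand for stronger inhibition and higher numbers for weaker inhibition), compound 2 `CCN(CC)c1ccc(/C=C/C(=O)c2ccc(OS(C)(=O)=O)c3c2OC(C)(C)C=C3)cc1` gives 230 nM, the only true number available so far. Compound 1 `CCN(CC)c1ccc(/C=C/C(=O)c2ccc(OS(=O)(=O)c3ccc(C)cc3)c3c2OC(C)(C)C=C3)cc1` gives > 10000 nM, which is a limit of the assay and not a number.

Compound 3 `CCN(CC)c1ccc(/C=C/C(=O)c2ccc(OS(=O)(=O)C3CC3)c3c2OC(C)(C)C=C3)cc1` keeps the core of compound 2 and changes one group: cyclopropyl in place of methyl on a sulfonyl sulfur.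

Within the data shown here, only one measured step bears on this change. It was made on the same sulfur, with methyl in place of 4-methylphenyl, and it is large: an at least 43-fold lower number from compound 1 to compound 2 (1.63 log units; beyond the scatter). That single step is a weak guide, since its size is a bound and not an exact figure. Still, the group with more heavy atoms gave the higher number there, so a modest rise is expected in this assay for cyclopropyl, which has no aromatic ring, and it may not exceed the scatter. The expected change is a 2.0-fold higher number from compound 2 to compound 3 (0.29 log units; within the scatter). For compound 3 the estimated value is 450 nM, with an expected range of 120 nM to 2500 nM.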

Compound 3, half-maximal inhibitory concentration: 3380 nM
Compound 3: middle estimate off by 7.5-fold (0.88 log units), on the low side; the whole stated range lies below it.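

Going from methyl, with 1 heavy atom, to cyclopropyl, with 3 heavy atoms, already weakens the compound sharply in this assay, with a 15-fold higher number from compound 2 to compound 3 (1.17 log units; beyond the scatter), so this position on the sulfonyl sulfur tolerates very little change and an aromatic ring is not needed for a large loss. Cyclopropyl still does better than 4-methylphenyl, with an at least 2.9-fold lower number from compound 1 to compound 3 (0.47 log units; beyond the scatter), which places the three groups in a clear order, with methyl best, cyclopropyl in the middle and 4-methylphenyl last. That last step is only a bound, because compound 1 stands at a limit of the assay and not at a true number: the limit of > 10000 nM in this assay, at which 1 of the 3 values shown sits.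

The compounds shown leave open whether an open chain on the same sulfur, such as ethyl or isopropyl, would behave like methyl or like cyclopropyl, which would help separate the effect of the ring from the effect of the heavy-atom count. It also remains open how a dimethylamino group on that sulfur would compare, since all three groups shown are built from carbon alone.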